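The compounds below may be only part of what the source reports. "The series", "measured", "known", "first", "only" and "open" are said of these compounds alone.

In an ADME assay on MCF7 cells (Homo sapiens) for cytotoxicity, read by MTT assay, with a stated time of 48 h (on this read-out lower numbers stand for stronger inhibition and higher numbers for weaker inhibition), compound 1 `C/C(=N\NC(=O)COc1cccc2cccnc12)c1ccccc1` gives only a limit of the assay, > 100000 nM. Compound 2 `C/C(=N\NC(=O)COc1cccc2cccnc12)c1ccccn1` likewise gives only a limit there, > 100000 nM. Compound 3 `C/C(=N\NC(=O)COc1cccc2cccnc12)c1ccc(Br)cc1` also gives only a limit, > 100000 nM. All three values sit at the limit of > 100000 nM in this assay, at which 3 of the 3 values shown sit, so the steps a step that the two limits leave unreadable from compound 1 to compound 2, a step that the two limits leave unreadable from compound 1 to compound 3 and a step that the two limits leave unreadable from compound 2 to compound 3 cannot be read in size, and compound 3 stands at that limit with nothing to set it apart from compound 1 or compound 2. Compound 4 `C/C(=N\NC(=O)COc1cccc2cccnc12)c1ccco1` differs from compound 3 by furan-2-yl in place of 4-bromophenyl on a carbon with a double bond to nitrogen. Of the measured steps, those on the same carbon, a step that the two limits leave unreadable from compound 1 to compound 2 and a step that the two limits leave unreadable from compound 2 to compound 3, bear most directly on this exchange, yet both remain unreadable because every value shown rests at the limit of > 100000 nM in this assay, at which 3 of the 3 values shown sit. Going by the values given here, no measured step in this assay shows anything beyond the scatter, and the step that the limit leaves unreadable from compound 3 to compound 4 is therefore expected to be none beyond the scatter. Compound 4 is accordingly estimated at 150000 nM, in a range from 30000 nM to 500000 nM, most probably again reported only as a limit.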

Compound 4, half-maximal inhibitory concentration: > 100000 nM
Compound 4 gave a limit, no number; the forecaster's own chance of this, stated with the estimate: 80%; the middle value does not contradict the limit.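

In this assay compound 4 also gives only a limit of > 100000 nM and no number. Its steps from compound 1, compound 2 and compound 3 therefore cannot be read in size: the limit of > 100000 nM in this assay, at which 4 of the 4 values shown sit. In this assay the compounds shown leave open whether any of these groups on the carbon with a double bond to nitrogen makes a difference.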